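The source may report more compounds than this note shows. Statements on the series, on what has been measured and on what is new or still open speak of the compounds shown alone.

Compound 2 `Cc1nc(NC(C2CC2)C2CC2)c2nc(C)n(-c3ccc(Cl)cc3)c2n1`: 11 nM
Compound 1 `COc1ccc(-n2c(C3CCCO3)nc3c(NC(C4CC4)C4CC4)nc(C)nc32)cc1`: 867 nM

In a functional assay on CHO cells for antagonist activity at corticotropin-releasing factor receptor 1 (Homo sapiens), read by cAMP accumulation (a lower number here means a stronger inhibitor, a higher number a weaker inhibitor), compound 2 gives 11 nM, the lowest of the two numbers measured. Compound 1 gives 867 nM, a far higher number, beyond the scatter. Compound 3 `Cc1nc(NC(C2CC2)C2CC2)c2nc(C)n(-c3ccc(OC(F)F)cc3)c2n1` differs from compound 2 by difluoromethoxy in place of chloro on an aromatic carbon. Among the measured compounds shown here, no step between measured compounds shows what this change does, so the expectation rests on the small size of the change alone. A modest move toward a higher number is expected, a 1.8-fold higher number from compound 2 to compound 3 (0.26 log units; within the scatter), hardly beyond the scatter. For compound 3 an inhibition constant of 20 nM is estimated, within a range of 6 nM to 70 nM.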

Compound 3, inhibition constant: 5 nM
Compound 3: middle estimate off by 4.0-fold (0.60 log units), on the high side; the measured number lies below the stated range.
By their numbers in this assay, from the lowest: compound 3; then compound 2; then compound 1.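

At this position, on an aromatic carbon para to a large group, difluoromethoxy is tolerated in place of chloro: in this assay the change gives a 2.2-fold lower number from compound 2 to compound 3 (0.34 log units; beyond the scatter), a modest step with no loss of inhibition. Among the compounds shown here, this is the first direct reading of the position, as compound 1 and compound 2 differ in more than one place. Nothing shown accounts for the direction of this step. Going by these compounds, whether trifluoromethoxy or a nitrile here would go the same way remains open, as does whether the step would hold with the other groups of compound 1.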